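From propargyl to pentyl: a step without a number

The compounds below may be only part of what the source reports. "The series", "measured", "known", "first", "only" and "open" are said of these compounds alone.

In a functional assay on HL-60 cells (Homo sapiens) for antiproliferative activity, read by MTT assay (a lower number here means a stronger inhibitor, a higher number a weaker inhibitor), compound 1 (`C#CC[C@@H]1O[C@H](COCc2ccccc2)[C@@H](OCc2ccccc2)[C@H](OCc2ccccc2)[C@H]1O`) is recorded as "not active" (no number reported) and so has no figure to place it. Compound 3 (`OC[C@H]1O[C@@H](Cc2ccccc2)[C@H](O)[C@@H](O)[C@@H]1O`) is likewise recorded as "not active" (no number reported) in this series. For the measured compounds named here, compound 2 (`O[C@@H]1[C@@H](OCc2ccccc2)[C@H](O)[C@@H](COCc2ccccc2)O[C@H]1Cc1ccccc1`) gives 35300 nM as the only number available. Compound 4 (`CCCCC[C@@H]1O[C@H](COCc2ccccc2)[C@@H](OCc2ccccc2)[C@H](OCc2ccccc2)[C@H]1O`) has butyl in place of ethynyl on a saturated chain carbon bound to a saturated ring carbon and is otherwise unchanged. Going by the values given here, no measured step shows what such a change does, so any shift in this assay is uncertain: at best a small move toward a stronger inhibitor, into measurable range. The estimate for compound 4 is 40000 nM with 15000 nM to 100000 nM as its expected range, if a number is reported at all.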

Compound 4, half-maximal inhibitory concentration: "not active" (no number reported)
For compound 4 the study gives words and no number; there is nothing to compare the estimate with.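

In this assay compound 1 and compound 4 are both reported in words alone, so no step can be read between them. The compounds shown leave open what going from propargyl to pentyl does to activity. Nothing shown bears on this result.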